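The compounds below may be only part of what the source reports. "The series", "measured", "known", "first", "only" and "open" are said of these compounds alone.

Measured so far:
compound 1, `N#CCN(Cc1ccccc1)Cc1ccc2ccccc2n1`: in an assay on HEK293 cells for binding affinity to Substance-K receptor (Rattus norvegicus), read by FRET, tested at 10 uM (a higher number here means more inhibition at the concentration tested (going by the name of the read-out), a lower number less inhibition), compound 1 gives 0%.
compound 2, `C#CCN(Cc1ccccc1)Cc1ccc2ccccc2c1`: in this assay compound 2 gives 0%.

Compound 2 stands level with compound 1 at the digits shown; the gap between the two readings lies within the scatter, so neither is set above the other. Within the data shown here, no step between the two is computed, and only the pair of readings is noted.

Compound 3, `O=C(CN(Cc1ccccc1)Cc1ccc2ccccc2c1)N1CCCCC1`, has not yet been measured. It derives from compound 2 by (piperidin-1-yl)carbonyl in place of ethynyl on a saturated chain carbon bound to an amine nitrogen. Among the measured compounds shown here, no measured step is available as a guide for this kind of change. Since compound 2 gives 0% in this assay, the step of a number 5 percentage points higher from compound 2 to compound 3 (within the scatter) is expected to be small, upward if anything, and possibly not beyond the scatter. Compound 3 is expected to give 5% in this assay, within a range from -5% to 25%.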

Compound 3, a percentage reported as inhibition, at one concentration (the size of the read-out at that concentration, not a potency): 0%
Compound 3: the middle estimate sits 5 percentage points above what was measured, within the range that was stated.
By their numbers in this assay, from the lowest: compounds 1, 2 and 3 (each within the scatter of the next).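

In this assay, among these compounds, the exchange of ethynyl for (piperidin-1-yl)carbonyl on a saturated chain carbon bound to an amine nitrogen shows no change at the digits printed from compound 2 to compound 3 (within the scatter) and is the first step read at this place. The result extends the series from a small propargyl group to ((piperidin-1-yl)carbonyl)methyl, which brings in a six-membered non-aromatic ring and a hydrogen-bond acceptor, yet it gives no ordering of these two groups. No other measurement bears on this result.

As far as these compounds go, whether a basic amine, a carboxylic acid or a longer chain carrying the piperidine amide at this carbon would give a reading that stands clear of the scatter in this assay remains open. Also open, from the compounds shown here alone, is whether any group at this place can give a reading that stands clear of the scatter while the shared core stays unchanged.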